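The source may hold more compounds than are shown below. What is called first, only, known or untested is meant among the compounds shown, and "the series" means these compounds.

Of the compounds shown here, two have been tested in an assay on isolated protein for inhibition of lactase/phlorizin hydrolase (Rattus norvegicus), read by colorimetric assay; a higher number here means a weaker inhibitor, a lower number a stronger inhibitor. Compound 1 `Cc1ccc(S(=O)(=O)Nc2ccc3c(c2)C(=O)N(Cc2ccc(Cl)cc2)C3=O)cc1` gives 155000 nM in this assay. Among the measured compounds shown here, compound 2 `Cc1ccc(S(=O)(=O)Nc2ccc3c(c2)C(=O)N(CCNc2ccc(O)c(O)c2)C3=O)cc1` gives 66600 nM in this assay, the lowest of the two numbers, and the only measured step, a 2.3-fold lower number from compound 1 to compound 2 (0.37 log units; beyond the scatter), describes how compound 2 separates from compound 1.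

Compound 3 `Cc1ccc(S(=O)(=O)Nc2ccc3c(c2)C(=O)N(CCCCBr)C3=O)cc1` has not yet been measured. It differs from compound 2 in one place: 2-bromoethyl in place of (3,4-dihydroxyphenyl)amino on a saturated chain carbon, two bonds along the chain from an amide-type nitrogen in a ring. The step from compound 1 to compound 2 is the only one that bears on this change, and it was modest; since the group that enters compound 3 leaves behind none of the hydrogen-bond donors or acceptors counted for the group that leaves, a move back toward the number of compound 1 seems more likely than a further drop. The expected step is a 2.0-fold higher number from compound 2 to compound 3 (0.29 log units; within the scatter) in this assay, and compound 3 is estimated at 130000 nM, within 50000 nM to 350000 nM.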

Compound 3, half-maximal inhibitory concentration: > 200000 nM
Compound 3: no number, only a limit; the forecaster's own chance of this, stated with the estimate: 15%; middle value at least 1.5-fold (0.18 log units) from the limit.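

Compound 3 gives no number, only a limit of the assay: the limit of > 200000 nM in this assay, at which 1 of the 3 values shown sits. Even so, putting 2-bromoethyl in place of (3,4-dihydroxyphenyl)amino, on a saturated chain carbon two bonds along the chain from an amide-type nitrogen in a ring, gives an at least 3.0-fold higher number from compound 2 to compound 3 (0.47 log units; beyond the scatter), so the first sign that the group at this place can change the reading in either direction now stands beside the modest earlier drop. Putting 3-bromopropyl in place of 4-chlorophenyl gives an at least 1.2-fold higher number from compound 1 to compound 3 (0.11 log units; that floor lies within the scatter), so that pair cannot be firmly ordered.

The change from compound 2 removes the ring, both hydroxyl groups and the nitrogen at once, and the compounds shown do not tell which of them matters. They also leave open how a plain phenylamino group, a carboxylic acid or a simple amine at the chain end would read.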